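The compounds below may be only part of what the source reports. "The series", "measured", "known", "first", "only" and "open" are said of these compounds alone.

Working notes on the series. Two compounds of the shared core have numbers in an assay on HEK293 cells for inhibition of acid ceramidase (Homo sapiens), with a stated time of 10 min (on this read-out lower numbers stand for stronger inhibition and higher numbers for weaker inhibition), so far. Compound 1 `O=C(NCCCCc1ccccc1)n1c(=O)oc2ccc(-c3ccccc3)cc21` gives 42 nM in this assay. Compound 2 `O=C(NCCCCc1ccccc1)n1c(=O)oc2cc([N+](=O)[O-])ccc21` gives 3 nM in this assay, the lowest of the two numbers; the gap to compound 1 lies beyond the usual scatter. Compounds 1 and 2 differ in more than one place, so their two values are set side by side without a counted step between them.

Compound 3 `O=C(NCCCCc1ccccc1)n1c(=O)oc2cc(F)ccc21` is not yet measured. It differs from compound 2 in one place: fluoro in place of nitro on an aromatic carbon. Within the data shown here, no measured pair isolates such a change, so the size of the step is open. On the two numbers at hand, the nitro compound 2 sits at the low end of the series, and a smaller single-atom group in its place is taken as more likely to move the number up than down; the step from compound 2 to compound 3 is expected to be a 6.7-fold higher number from compound 2 to compound 3 (0.82 log units; beyond the scatter) in this assay. Compound 3 is therefore estimated at 20 nM in this assay, with a range from 5 nM to 80 nM.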

Compound 3, half-maximal inhibitory concentration: 31 nM
Compound 3: the middle estimate sits 1.6-fold (0.19 log units) below what was measured; the range from low to high includes it.
By their numbers in this assay, from the lowest: compound 2; then compounds 3 and 1 (each within the scatter of the next).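

Among these compounds, this is the first single-place change: on this aromatic carbon, meta to a fused ring and para to a fused ring, fluoro in place of nitro gives a 10-fold higher number from compound 2 to compound 3 (1.01 log units; beyond the scatter) in this assay, so the number at this position clearly responds to the group it carries. The exchange alters several counted features at once, with nitro bringing 3 heavy atoms and 2 hydrogen-bond acceptors and fluoro bringing 1 heavy atom and no hydrogen-bond acceptors, and this one pair cannot separate their contributions. No measurement at hand bears on what lies behind the step.

From the compounds shown here alone, how a chloro, methoxy or amino group at this carbon, or a plain hydrogen, would stand against nitro and fluoro remains open, and with it whether nitro is unusual here or fluoro is. Also open, going by these compounds, is whether the same exchange would give a step of similar size on another aromatic carbon of the ring, or with a longer chain in place of the one on the shared core.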